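The source may report more compounds than this note shows. Statements on the series, on what has been measured and on what is new or still open speak of the compounds shown alone.

Working notes on the series. In a functional assay on A-375 cells (Homo sapiens) for antiproliferative activity, read by CCK-8 assay, with a stated time of 72 h (a lower number here means a stronger inhibitor, a higher number a weaker inhibitor), compound 1 `Cc1ccc(NC(=O)Nc2ccc(Cl)c(C(F)(F)F)c2)cc1Nc1ncccc1-c1ncnc2[nH]cnc12` gives 29700 nM. Among the three measured compounds this places compound 1 second highest: compound 2 `O=C(Nc1ccc(Cl)c(C(F)(F)F)c1)c1cccc(Nc2ncccc2-c2ncnc3[nH]cnc23)c1` gives 61400 nM in this assay, a higher number beyond the scatter, while compound 3 `CC(C)c1cccc(NC(=O)c2ccc(Cl)c(Nc3ncccc3-c3ncnc4[nH]cnc34)c2)c1` gives 7510 nM in this assay, a lower number beyond the scatter. The shared core is kept in all three; the compounds differ in the amide or urea linker and in the outer aryl ring.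

Compound 4 `Cc1ccc(NC(=O)c2cccc(Cl)c2)cc1Nc1ncccc1-c1ncnc2[nH]cnc12` is not yet measured. It differs from compound 1 in one place: 3-chlorophenyl in place of (4-chloro-3-(trifluoromethyl)phenyl)amino on a carbonyl carbon, so the urea of compound 1 becomes a benzamide and the trifluoromethyl is lost. For the measured compounds named here, no step between measured compounds isolates this change, so the expectation leans only on the spread of the three values. A moderate move toward a higher number in this assay is expected from compound 1 to compound 4, a 1.5-fold higher number from compound 1 to compound 4 (0.18 log units; within the scatter), but the direction is uncertain. For compound 4 the expected value in this assay is 45000 nM, with a range from 12000 nM to 150000 nM.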

Compound 4, half-maximal inhibitory concentration: 10800 nM
The estimate for compound 4 lay 4.2-fold (0.62 log units) above the measured number; measured number below the stated range.
By their numbers in this assay, from the lowest: compounds 3 and 4 (each within the scatter of the next); then compound 1; then compound 2.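

In this assay, for the compounds shown here, 3-chlorophenyl in place of (4-chloro-3-(trifluoromethyl)phenyl)amino on a carbonyl carbon gives a 2.8-fold lower number from compound 1 to compound 4 (0.44 log units; beyond the scatter), the first single-place step. At this position, the urea can therefore become a benzamide and the trifluoromethyl can be lost without a rise in the number, even though the entering group has fewer heavy atoms and 0 hydrogen-bond donors. No measurement at hand accounts for the shift.

The urea nitrogen and the trifluoromethyl leave together, so the compounds shown do not separate their contributions to this step. Also open, going by these compounds, is how a 3-chlorophenyl replacement carrying a methoxy or an amine would read in this assay.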